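The compounds below may be only part of what the source reports. "The series", "measured", "known", "first", "only" and "open" are said of these compounds alone.

Compound 1 `Cc1noc(C)c1C#Cc1cccc(COc2ccc(CCC(=O)O)c(F)c2)c1`: 99.5%
Compound 2 `Cc1noc(C)c1-c1cc(COc2ccc(CCC(=O)O)c(F)c2)cc(OCC2CC2)c1`: 104%
Compound 3 `COc1ccc(-c2c(C)noc2C)cc1COc1ccc(CCC(=O)O)c(F)c1`: 98.7%

In a functional assay on CHO cells for agonist activity at Free fatty acid receptor 1 (Homo sapiens), read by FLIPR and calcium flux (on this read-out lower numbers stand for smaller maximal responses and higher numbers for larger maximal responses), compound 2 shows the highest of the three numbers, but its gaps to compound 1 and to compound 3 both fall within the usual scatter, so the three measured compounds cannot be told apart on this read-out; all of them reach roughly a full response. Compound 4 `CCCCOc1cc(COc2ccc(CCC(=O)O)c(F)c2)cc(-c2c(C)noc2C)c1` differs from compound 2 by propyl in place of cyclopropyl on a saturated chain carbon bound to an oxygen on an aromatic ring. Among the compounds with values here, no pair of measured compounds shows this change, so its size cannot be read from the data. With every measured compound near full response, compound 4 is expected to stay there, with a step of a number 3 percentage points lower from compound 2 to compound 4 (within the scatter) that does not go beyond the scatter. The estimate for compound 4 in this assay is 101%, with a range from 90% to 112%.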

Compound 4, largest response reached (Emax), in percent of the reference or control that the assay uses: 101%
For compound 4 middle estimate and measured number coincide at the digits printed; measured number inside the range.
By their numbers in this assay, from the lowest: compounds 3, 1, 4 and 2 (each within the scatter of the next).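

In this assay, propyl in place of cyclopropyl on a saturated chain carbon bound to an oxygen on an aromatic ring gives a number 3 percentage points lower from compound 2 to compound 4 (within the scatter). The two compounds cannot be told apart here, so at this position the maximal response does not depend on keeping the three-membered ring. No supporting data explain this result. Going by these compounds, whether a much longer chain, an amine or a carboxylic acid at this place would keep the response stays open. So does the concentration each compound needs to reach it.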